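Swapping a Piperidine for a Pyridinone on the Core

The compounds below may be only part of what the source reports. "The series", "measured", "known", "first", "only" and "open" are said of these compounds alone.

Compound 1: `CCc1cc(OC)c(S(C)(=O)=O)cc1C(=O)N=C(N)N` gives 30 nM in a functional assay for inhibition of sodium/hydrogen exchanger (Oryctolagus cuniculus); a lower number here means a stronger inhibitor, a higher number a weaker inhibitor
Compound 2: `CCc1cc(N2CCCCC2)c(S(C)(=O)=O)cc1C(=O)N=C(N)N` gives 25 nM in this assay

Compound 2 holds the lowest of the two numbers shown, but the step of a 1.2-fold lower number from compound 1 to compound 2 (0.08 log units; within the scatter) is within the scatter, so the two compounds cannot be told apart. Compound 3, `CCc1cc(-n2ccc(=O)cc2)c(S(C)(=O)=O)cc1C(=O)N=C(N)N`, carries the change (a group of 7 heavy atoms (5 carbon, 1 nitrogen, 1 oxygen; one six-membered aromatic ring with 1 hetero atom) in place of a group of 6 heavy atoms (5 carbon, 1 nitrogen; one six-membered non-aromatic ring with 1 hetero atom), on an aromatic carbon). Within the data shown here, only one measured step bears on the site, and it moved little. Compound 3 is therefore expected to change by about a 1.4-fold higher number from compound 2 to compound 3 (0.15 log units; within the scatter), no more than the scatter. The estimate for compound 3 in this assay is 35 nM, ranging from 12 nM to 100 nM.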

Compound 3, half-maximal inhibitory concentration: 930 nM
Compound 3: middle estimate off by 27-fold (1.42 log units), on the low side, outside the stated range (above it).
By their numbers in this assay, from the lowest: compounds 2 and 1 (each within the scatter of the next); then compound 3.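

In this assay this position proves far from indifferent to what it carries: the new six-membered aromatic ring gives a 37-fold higher number from compound 2 to compound 3 (1.57 log units; beyond the scatter) and also a 31-fold higher number from compound 1 to compound 3 (1.49 log units; beyond the scatter). The close numbers of compound 1 and compound 2 therefore did not mean that any group is accepted here. Nothing measured here explains this loss.

Still open, from the compounds shown here alone, is whether the aromatic ring or its carbonyl oxygen matters more. A phenyl group or a saturated piperidin-4-one ring at the same place could help separate the two.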